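Methylating the phenol of compound 2

The source may report more compounds than this note shows. Statements on the series, on what has been measured and on what is new or still open speak of the compounds shown alone.

Measured so far in a functional assay on Hs-578T cells (Homo sapiens) for inhibition, read by sulforhodamine B assay, with a stated time of 48 h, tested at 10 uM; a lower number here means a stronger effect, a higher number a weaker effect of the compound at the concentration tested:
- compound 1 `O=C(Nc1cccc(-n2cc(-c3ccncc3)c(-c3cc(O)cc(Cl)c3)n2)c1)Nc1ccc(Cl)c(C(F)(F)F)c1`: 21.7%
- compound 2 `O=C(Nc1cccc(-n2cc(-c3ccncc3)c(-c3cc(O)cc(Cl)c3)n2)c1)Nc1ccc(Cl)c(Cl)c1`: -6.42%
- compound 3 `COc1cc(Cl)cc(-c2nn(-c3cccc(NC(=O)Nc4cc(C(F)(F)F)cc(C(F)(F)F)c4)c3)cc2-c2ccncc2)c1`: 5.82%

Compound 2 gives the lowest of the three numbers in this assay, which here means the strongest effect at the tested concentration. Its nearest neighbour is compound 3, whose value stands higher by more than the usual scatter, and the furthest is compound 1, which lies higher still. Among the measured compounds shown here, the one change already measured, a number 28.1 percentage points lower from compound 1 to compound 2 (beyond the scatter), concerns the urea end of the molecule and is a modest step.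

Compound 4 `COc1cc(Cl)cc(-c2nn(-c3cccc(NC(=O)Nc4ccc(Cl)c(Cl)c4)c3)cc2-c2ccncc2)c1` is not yet measured. It differs from compound 2 in one place, (methyl in place of hydrogen on an oxygen on an aromatic ring), so the hydroxy becomes a methoxy while the urea end stays as in compound 2. For the measured compounds named here, no measured pair isolates this change: compound 3 carries the methoxy but also a different urea aryl, so its values beside those of compound 2 show only that the two compounds sit some way apart. Going by the values given here, with no direct precedent, no step beyond the scatter is assumed, and the estimate for compound 4 is 2%, within -18% to 25%, meaning an expected step of a number 8.4 percentage points higher from compound 2 to compound 4 (within the scatter).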

Compound 4, a percentage reported as activity, at one concentration (the size of the read-out at that concentration, not a potency): 28.5%
Estimate against measurement, compound 4: 26.5 percentage points below; the whole stated range lies below it.
By their numbers in this assay, from the lowest: compound 2; then compound 3; then compounds 1 and 4 (each within the scatter of the next).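

In this assay, putting a methyl on the oxygen of the 3-chloro-5-hydroxyphenyl group gives a number 34.9 percentage points higher from compound 2 to compound 4 (beyond the scatter), so this position is far from indifferent to the change from hydroxy to methoxy. Among the compounds shown here, this is the first pair that isolates the position with the urea end held constant, and the free hydroxy goes with the stronger effect at the tested concentration; the step counts as large, while the change at the urea end, a number 28.1 percentage points lower from compound 1 to compound 2 (beyond the scatter), counts as modest. Nothing shown here accounts for the loss, as no measurement of any property of the two groups accompanies it.

As far as these compounds go, whether the same step would appear with other urea ends stays open: compound 1 and compound 3 each carry a different urea aryl, so neither forms a one-place pair with the other compounds across this change. Also open, from the compounds shown here alone, is how an amine, an ethoxy group or a carboxylic acid at this place on the ring would read in this assay, and so whether the hydroxy itself matters or only the added methyl.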